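This account rests on a few compounds, and the source may have more. Where it says the series, first, only, none or still open, it means among the compounds named here.

Measured so far, with values in a functional assay on PC-3 cells (Homo sapiens) for antiproliferative activity, read by MTT assay, with a stated time of 48 h; on this read-out higher numbers stand for weaker inhibition and lower numbers for stronger inhibition:
- compound 1 `O=C(Nc1cc(Sc2ncnc3nc[nH]c23)c(O)c2ccccc12)c1ccc(Cl)cc1`: compound 1 gives 66400 nM.
- compound 2 `COc1ccc(/C=C/C(=O)Nc2cc(Sc3ncn[nH]3)c(O)c3ccccc23)cc1OC`: compound 2 gives > 100000 nM, a limit of the assay.
- compound 3 `O=C(Nc1cc(Sc2ncnc3nc[nH]c23)c(O)c2ccccc12)c1ccc([N+](=O)[O-])cc1`: compound 3 gives > 100000 nM, likewise a limit of the assay.

Among the measured compounds shown here, compound 1 stands alone as the only number in this assay; the other two values are limits, so compound 1 cannot be ordered against them. For the measured compounds named here, the single measured step, an at least 1.5-fold higher number from compound 1 to compound 3 (0.17 log units; that floor lies within the scatter), ends at a limit, as described in the limit of > 100000 nM in this assay, at which 2 of the 3 values shown sit, and its floor lies within the scatter, so it shows no resolved change.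

Compound 4 `O=C(Nc1cc(Sc2ncn[nH]2)c(O)c2ccccc12)c1ccc(Cl)cc1` differs from compound 1 by a group of 5 heavy atoms (2 carbon, 3 nitrogen; one five-membered aromatic ring with 3 hetero atoms) in place of a group of 9 heavy atoms (5 carbon, 4 nitrogen; one five-membered aromatic ring with 2 hetero atoms, one six-membered aromatic ring with 2 hetero atoms), on a sulfur. Going by the values given here, no measured step covers this change. Compound 2 carries the same 1H-1,2,4-triazol-5-yl group on the sulfur with a different amide, and compound 2 shows only a limit. Compound 1 itself already lies near the limit described in the limit of > 100000 nM in this assay, at which 2 of the 3 values shown sit. On that basis, the expected step in this assay is a 1.4-fold higher number from compound 1 to compound 4 (0.13 log units; within the scatter), read as none beyond the scatter or a shift toward weaker inhibition, with a real chance that only a limit is reported. Compound 4 is estimated at 90000 nM, with a range from 40000 nM to 200000 nM.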

Compound 4, half-maximal inhibitory concentration: 5520 nM
The estimate for compound 4 lay 16-fold (1.21 log units) above the measured number, outside the stated range (below it).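

In this assay, the group on the sulfur proves to be a position that moves the read-out, with the step to the 1H-1,2,4-triazol-5-yl group being a 12-fold lower number from compound 1 to compound 4 (1.08 log units; beyond the scatter). Among the compounds shown here, this is the first change resolved beyond the scatter, and it shows that, with the amide of compound 1 held constant, the group of two aromatic rings is not required for the stronger inhibition seen here, since the single five-membered ring with fewer heavy atoms gives the lower number. The triazolyl group does not secure activity whatever the amide, as compound 2, which carries the same group on the sulfur with a different amide, gives > 100000 nM, a limit of the assay.

As far as these compounds go, how far the effect of the group on the sulfur depends on the amide stays open, and the series offers little to order it by: the limit of > 100000 nM in this assay, at which 2 of the 4 values shown sit. Also open is whether the five-membered ring itself matters, which a short alkyl chain, a carboxylic acid or an amine-bearing chain on the same sulfur would test.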